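The source may hold more compounds than are shown below. What is called first, only, known or untested is meant among the compounds shown, and "the series" means these compounds.

Measured in a functional assay on K562 cells (Homo sapiens) for antiproliferative activity, with a stated time of 72 h; a higher number here means a weaker inhibitor, a lower number a stronger inhibitor:

- compound 1 `OC[C@H]1O[C@@H](n2cnc3c(NCc4ccccc4F)ncnc32)[C@H](O)[C@@H]1O`: 33200 nM
- compound 2 `COc1ccccc1CNc1ncnc2c1ncn2[C@@H]1O[C@H](CO)[C@@H](O)[C@H]1O`: 89000 nM
- compound 3 `OC[C@H]1O[C@@H](n2cnc3c(NCc4ccc(Cl)c(Cl)c4)ncnc32)[C@H](O)[C@@H]1O`: 10800 nM

All three share one core and differ only in the aromatic group on the chain. Of these, compound 3 stands lowest at 10800 nM, and its steps to both others lie beyond the scatter, so it is the strongest inhibitor of the three.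

Compound 4 `OC[C@H]1O[C@@H](n2cnc3c(NCc4ccc(F)cc4Cl)ncnc32)[C@H](O)[C@@H]1O` has not yet been measured. It differs from compound 3 only in that aromatic group: 2-chloro-4-fluorophenyl in place of 3,4-dichlorophenyl on a saturated chain carbon bound to a nitrogen on an aromatic ring. This places 2-chloro-4-fluorophenyl in place of 3,4-dichlorophenyl on a saturated chain carbon bound to a nitrogen on an aromatic ring.

Among the compounds with values here, no measured compound carries this exact group, so the evidence is indirect. The closest guide is a 3.1-fold lower number from compound 1 to compound 3 (0.49 log units; beyond the scatter), a swap at the same place between a group with fluorine and one with chlorine. The wider an 8.2-fold lower number from compound 2 to compound 3 (0.92 log units; beyond the scatter) shows how far such swaps can reach, and a 2.7-fold higher number from compound 1 to compound 2 (0.43 log units; beyond the scatter) is a modest step too. The new group holds one chlorine and one fluorine, so a value between those of compound 3 and compound 1 seems a reasonable expectation.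

The expected move is a 1.9-fold higher number from compound 3 to compound 4 (0.27 log units; within the scatter), a small step toward a higher number that may not clear the scatter. For compound 4 the estimated value is 20000 nM, with an expected range from 8000 nM to 45000 nM.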

Compound 4, half-maximal inhibitory concentration: 15600 nM
The estimate for compound 4 lay 1.3-fold (0.11 log units) above the measured number, within the range that was stated.
By their numbers in this assay, from the lowest: compounds 3 and 4 (each within the scatter of the next); then compound 1; then compound 2.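

In this assay, the swap of 3,4-dichlorophenyl for 2-chloro-4-fluorophenyl gives a 1.4-fold higher number from compound 3 to compound 4 (0.16 log units; within the scatter), so at this place on a saturated chain carbon bound to a nitrogen on an aromatic ring, these two groups cannot be told apart, and a second chlorine is not required to reach this level. Within the data shown here, compound 3 was previously the only chlorine-bearing compound, but the two other steps, a 2.1-fold lower number from compound 1 to compound 4 (0.33 log units; beyond the scatter) and a 5.7-fold lower number from compound 2 to compound 4 (0.76 log units; beyond the scatter), now set a second such compound apart from both the 2-fluorophenyl and the 2-methoxyphenyl compounds, a pattern that holds across these four compounds with none going against it. Nothing in the data shown explains why these groups rank as they do.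

The compounds shown leave open how a plain phenyl with no substituent, or a phenyl carrying a single chlorine and no other group, would compare, so the share of each halogen in this pattern cannot be separated. They also leave open whether bromine or trifluoromethyl on the ring, or a longer chain between the nitrogen and the ring, would keep the number in this range.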